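The compounds below may be only part of what the source reports. "The series", "measured", "known", "first", "only" and "open" are said of these compounds alone.

Among the compounds with values here, in a functional assay on Jurkat E6.1 cells (Homo sapiens) for cytotoxicity, read by MTT assay, with a stated time of 24 h (on this read-out lower numbers stand for stronger inhibition and higher numbers for weaker inhibition), compound 1 `COC(=O)/C(=C\c1ccc(O)cc1)Sc1ccnc2cc(Cl)ccc12` gives 5180 nM and compound 2 `COC(=O)/C(=C\c1ccc(OC(=O)c2ccccc2OC)cc1)Sc1ccnc2cc(Cl)ccc12` gives 44700 nM as the higher of the two numbers so far. Within the data shown here, the one measured step of an 8.6-fold higher number from compound 1 to compound 2 (0.94 log units; beyond the scatter) is modest but beyond the scatter, and it places a (2-methoxyphenyl)carbonyl in place of hydrogen on an oxygen on an aromatic ring. Compound 3 `COC(=O)/C(=C\c1ccc(OC(=O)c2cc(OC)cc(OC)c2OC)cc1)Sc1ccnc2cc(Cl)ccc12` departs from compound 2 in a single place, with 2,3,5-trimethoxyphenyl in place of 2-methoxyphenyl on a carbonyl carbon as the change: 2,3,5-trimethoxyphenyl in place of 2-methoxyphenyl on a carbonyl carbon. Among the measured compounds shown here, no measured step varies this group, so the one available step bears on the change only loosely and gives no direction. The estimated step of a 1.1-fold lower number from compound 2 to compound 3 (0.05 log units; within the scatter) is therefore expected to stay within the scatter. Compound 3 is estimated at 40000 nM with an expected range from 15000 nM to 100000 nM in this assay once it is measured.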

Compound 3, half-maximal inhibitory concentration: 15600 nM
Compound 3: middle estimate off by 2.6-fold (0.41 log units), on the high side; the range from low to high includes it.
By their numbers in this assay, from the lowest: compound 1; then compound 3; then compound 2.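

In this assay the group on the carbonyl carbon proves to matter, since 2,3,5-trimethoxyphenyl in place of 2-methoxyphenyl gives a 2.9-fold lower number from compound 2 to compound 3 (0.46 log units; beyond the scatter) and the position therefore responds to the aryl group itself and not only to the replacement of the hydrogen on the oxygen. This step runs in the opposite direction to the earlier one and takes back part of that rise, though compound 3 at 15600 nM still reads higher than compound 1, which gives 5180 nM in this assay. No measurement at hand explains the change.

Which of the methoxy groups accounts for the step stays open, as only these two substitution patterns can be compared. Also open, on these data alone, is how an unsubstituted phenyl, a dimethylamino-bearing phenyl or a simple alkyl chain would read on the same carbonyl carbon.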